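Swapping phenyl for pyridin-2-yl on a hydrazide urea

The source may hold more compounds than are shown below. What is called first, only, known or untested is meant among the compounds shown, and "the series" means these compounds.

Measured compounds:
compound 1 `CC(=O)NNC(=O)NCc1ccccc1` gives > 100 mg/kg
compound 2 `CC(=O)NN(C(=O)NCc1ccccc1)c1ccccc1` gives > 30 mg/kg

Both of these values are limits of a functional assay on the whole organism with Mus musculus as the target, in the maximal electroshock model (on this read-out higher numbers stand for an effect only at larger amounts of compound and lower numbers for an effect already at smaller amounts), not numbers. Compound 1 stands at the limit of > 100 mg/kg in this assay, at which 1 of the 2 values shown sits. Compound 2 stands at the limit of > 30 mg/kg in this assay, at which 1 of the 2 values shown sits. The step that the two limits leave unreadable from compound 1 to compound 2 therefore cannot be read. Compound 3 `CC(=O)NN(C(=O)NCc1ccccc1)c1ccccn1` differs from compound 2 by pyridin-2-yl in place of phenyl on an amide-type nitrogen. Among the measured compounds shown here, no measured step bears on this change, and the only measured step is unreadable. Compound 3 is thus expected to land near 60 mg/kg, in a range from 20 mg/kg to 300 mg/kg, most likely again reported only as a limit. For compound 3 the expected step is a step that the limit leaves unreadable from compound 2 to compound 3, none beyond the scatter.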

Compound 3, dose for half-maximal effect: > 30 mg/kg
Compound 3: only a limit was reported; the forecaster's own chance of this, stated with the estimate: 70%; the middle value lies beyond the limit too.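

Among the compounds shown here, compound 1, compound 2 and compound 3 all carry limits rather than numbers in this assay, so no step among them can be read. Going by these compounds, whether pyridin-2-yl and phenyl differ at all on this amide-type nitrogen stays open.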